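The source may report more compounds than this note shows. Statements on the series, on what has been measured and on what is new or still open speak of the compounds shown alone.

In a functional assay on MKN-45 cells (Homo sapiens) for inhibition, with a stated time of 72 h (on this read-out lower numbers stand for stronger inhibition and higher numbers for weaker inhibition), compound 1 (`COc1ccc(S(=O)(=O)N2CCc3cccc(-c4ccc(N(C)C)cc4)c32)cc1`) gives 237 nM. Compound 2 (`COc1ccc(S(=O)(=O)n2ccc3cccc(-c4ccc(C#N)cc4)c32)cc1`) gives 143 nM, and compound 3 (`COc1ccc(S(=O)(=O)n2ccc3cccc(-c4ccc(F)cc4)c32)cc1`) gives 170 nM. Compound 1 lies within the scatter of both of the others, so these numbers set no order among the three.

Compound 4 (`COc1ccc(S(=O)(=O)N2CCc3cccc(-c4ccccc4)c32)cc1`) keeps the core of compound 1 and differs from it in one place: hydrogen in place of dimethylamino on an aromatic carbon. In words, this is hydrogen in place of dimethylamino on an aromatic carbon, which turns 4-(dimethylamino)phenyl into phenyl.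

Among the compounds with values here, only one measured step bears on this change: a 1.2-fold higher number from compound 2 to compound 3 (0.08 log units; within the scatter). It exchanges one group for another at a similar place, and it stays within the scatter. It is only a loose guide, since it was measured on a different core and involves neither dimethylamino nor a bare hydrogen. Within the data shown here, no measured pair shows what removing a group from this ring does.

With so little evidence, no change beyond the scatter is expected, and the direction is not firm. The estimated step is a 1.2-fold lower number from compound 1 to compound 4 (0.07 log units; within the scatter). For compound 4, the expected value in this assay is 200 nM, with an estimated range from 90 nM to 450 nM.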

Compound 4, half-maximal inhibitory concentration: 117 nM
Compound 4: the middle estimate sits 1.7-fold (0.23 log units) above what was measured; the measured number falls inside the stated range.
By their numbers in this assay, from the lowest: compounds 4, 2, 3 and 1 (each within the scatter of the next, the first and the last beyond it).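

Removing the dimethylamino group in this assay gives a 2.0-fold lower number from compound 1 to compound 4 (0.31 log units; beyond the scatter), a modest step, but the first in this series to pass beyond the scatter. Within the data shown here, the only earlier step on this ring, a 1.2-fold higher number from compound 2 to compound 3 (0.08 log units; within the scatter), exchanged one group for another on a different core and stayed within the scatter, so it could not show that this position responds to any change. The new step shows that, on the core of compound 1, the aromatic carbon para to a large group can carry plain hydrogen with no loss in this read-out, and that the 4-(dimethylamino)phenyl group can be cut back to phenyl; nothing in the data at hand gives a reason for the step.

The compounds shown leave open whether a smaller amine such as a primary amino group, or a carboxylic acid or a morpholine ring, would behave like dimethylamino or like hydrogen at this carbon. They also leave open whether the same change from a substituted phenyl to phenyl would give a similar step on the core of compound 2 and compound 3.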